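Phenyl in Place of 2-Chloro-4-fluorophenyl on Compound 3

This account rests on a few compounds, and the source may have more. Where it says the series, first, only, none or still open, it means among the compounds named here.

In an ADME assay on microsomes from liver (Rattus norvegicus) for metabolic stability, read by LC-MS, in the presence of a further agent that is not named here (on this read-out higher numbers stand for fast clearance and lower numbers for slow clearance), compound 3 `Cc1ncc(C)n2nc(-c3ccn4cc(-c5ccc(F)cc5Cl)nc4n3)nc12` gives 11.5 mL.min-1.g-1 which lies within the scatter of compound 2 `Cc1ncc(C)n2nc(-c3ccn4cc(-c5ccc(Br)cc5)nc4n3)nc12` at 15 mL.min-1.g-1 while compound 1 `COc1cccnc1-c1nc2ccc(-c3nc4c(C)ncc(C)n4n3)cc2[nH]1` at 5.4 mL.min-1.g-1 lies lower, beyond the scatter. Compound 4 `Cc1ncc(C)n2nc(-c3ccn4cc(-c5ccccc5)nc4n3)nc12` carries phenyl in place of 2-chloro-4-fluorophenyl on an aromatic carbon. Within the data shown here, the only measured step at this place is a 1.3-fold lower number from compound 2 to compound 3 (0.12 log units; within the scatter) and it stays within the scatter. Among the measured compounds shown here, that step exchanges one halogen-bearing phenyl for another, so no measurement yet shows a phenyl without halogen. The step expected is a 1.0-fold higher number from compound 3 to compound 4 (0.02 log units; within the scatter) and thus none beyond the scatter. Compound 4 is estimated at 12 mL.min-1.g-1 with an expected range of 6 mL.min-1.g-1 to 24 mL.min-1.g-1 around that figure.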

Compound 4, intrinsic clearance in microsomes: 5.6 mL.min-1.g-1
Estimate against measurement, compound 4: 2.1-fold (0.33 log units) above; measured number below the stated range.
By their numbers in this assay, from the lowest: compounds 1 and 4 (each within the scatter of the next); then compounds 3 and 2 (each within the scatter of the next).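

In this assay, phenyl without halogen separates from both halogen-bearing compounds, with a 2.1-fold lower number from compound 3 to compound 4 (0.31 log units; beyond the scatter) and a 2.7-fold lower number from compound 2 to compound 4 (0.43 log units; beyond the scatter), whereas the exchange of one halogen-bearing phenyl for another gave only a 1.3-fold lower number from compound 2 to compound 3 (0.12 log units; within the scatter). At this aromatic carbon, then, the presence or absence of halogen on the phenyl shifts the clearance number more than the choice between these two halogen patterns does. Nothing available explains this difference. The compounds shown leave open whether a lone fluoro or a lone chloro on the phenyl would give a number nearer that of compound 3 or compound 4. They also leave open how a methoxy group or an amine on this ring would read.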